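The source may hold more compounds than are shown below. What is called first, only, known or untested is meant among the compounds shown, and "the series" means these compounds.

Two compounds of the series carry a result in a functional assay on A549 cells (Homo sapiens) for antiproliferative activity, read by MTT assay; a higher number here means a weaker inhibitor, a lower number a stronger inhibitor. Compound 1 `O=C1N=C(N2CCC[C@H]2C(=O)Nc2ccc3ncnc(Nc4cccc(Cl)c4)c3c2)S/C1=C/c1ccc(Br)s1` gives only a limit of the assay, > 50000 nM. Compound 2 `O=C1N=C(N2CCC[C@H]2C(=O)Nc2ccc3ncnc(Nc4cccc(Cl)c4)c3c2)S/C1=C/c1cccnc1` gives 10400 nM in this assay and so holds the only number shown. The result of compound 1 is a limit of the assay. Compound 2 therefore has no measured neighbour to rank against. Going by the values given here, the one measured step, an at least 4.8-fold lower number from compound 1 to compound 2 (0.68 log units; beyond the scatter), is the whole of the evidence; it rests on (the limit of > 50000 nM in this assay, at which 1 of the 2 values shown sits), so its size is known only as a bound.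

Compound 3 `O=C1N=C(N2CCC[C@H]2C(=O)Nc2ccc3ncnc(Nc4cccc(Cl)c4)c3c2)S/C1=C/c1ccc(-c2ccccc2)cc1` is the next compound: 4-phenylphenyl in place of pyridin-3-yl on a double-bonded chain carbon bound to a double-bonded ring carbon. Among the compounds with values here, no measured step covers this change. The step from compound 1 to compound 2 shows that the group in this place moves the number beyond the scatter, but the direction for a 4-phenylphenyl group is not covered. Compound 3 is expected to give a weaker number than compound 2, the step being a 2.4-fold higher number from compound 2 to compound 3 (0.38 log units; beyond the scatter); the estimate for compound 3 is 25000 nM, in a range of 8000 nM to 80000 nM, with a fair chance that this assay returns only a limit.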

Compound 3, half-maximal inhibitory concentration: 24200 nM
Compound 3: the middle estimate sits 1.0-fold (0.01 log units) above what was measured; low and high end bracket the measured number.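

The position now carries a step between two measured numbers in this assay: a 2.3-fold higher number from compound 2 to compound 3 (0.37 log units; beyond the scatter), with 4-phenylphenyl entering for pyridin-3-yl on the double-bonded chain carbon bound to a double-bonded ring carbon. The other new step, an at least 2.0-fold lower number from compound 1 to compound 3 (0.31 log units; beyond the scatter), puts 4-phenylphenyl on the stronger side of 5-bromothiophen-2-yl, so the three groups rank pyridin-3-yl, 4-phenylphenyl, 5-bromothiophen-2-yl from lower number to higher. Compound 1 remains a limit of the assay, so the far end of this order is fixed only as a bound: the limit of > 50000 nM in this assay, at which 1 of the 3 values shown sits.

All three groups shown at this place are aromatic, which leaves open whether a non-aromatic group such as a morpholine ring, a carboxylic acid or a plain alkyl chain would give a lower number than compound 2 at 10400 nM. A plain phenyl group would also be needed to separate the ring nitrogen of pyridin-3-yl from the second ring of 4-phenylphenyl, since these two groups differ in both at once.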